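This account rests on a few compounds, and the source may have more. Where it says the series, first, only, none or still open, it means among the compounds named here.

In this set, four compounds share one core and differ at two places. Compound 3 `O=C(CSc1nc2ccc(NC(=O)c3ccc([N+](=O)[O-])cc3)cc2s1)NCc1ccccc1` carries the (4-nitrophenyl)carbonyl group on the amide-type nitrogen and an unsubstituted benzyl at the other end. In a functional assay on HepG2 cells (Homo sapiens) for cytotoxicity, read by MTT assay, with a stated time of 48 h (a lower number here means a stronger inhibitor, a higher number a weaker inhibitor), compound 3 gives > 100000 nM, which is a limit of the assay and not a number. Compound 1 `O=C(CSc1nc2ccc(NC(=O)CCl)cc2s1)NCc1ccccc1` differs from compound 3 in one place: chloromethyl in place of 4-nitrophenyl on a carbonyl carbon. In this assay compound 1 gives 1100 nM. That change made an at least 90-fold lower number from compound 3 to compound 1 (1.95 log units; beyond the scatter).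

Compound 2 `O=C(CSc1nc2ccc(NC(=O)c3ccc([N+](=O)[O-])cc3)cc2s1)NCc1ccc(Cl)cc1` differs from compound 3 in the other place: chloro in place of hydrogen on an aromatic carbon. In this assay compound 2 gives > 100000 nM, again a limit of the assay rather than a number. Between these two the data show a step that the two limits leave unreadable from compound 2 to compound 3, because of the limit of > 100000 nM in this assay, at which 2 of the 3 values shown sit.

Compound 4 `O=C(CSc1nc2ccc(NC(=O)CCl)cc2s1)NCc1ccc(Cl)cc1` has not yet been measured in this assay. It differs from compound 2 by chloromethyl in place of 4-nitrophenyl on a carbonyl carbon, which is the same change, at the same place, that turned compound 3 into compound 1. With compound 2 sitting at the limit, the step to compound 4 is expected to resemble an at least 90-fold lower number from compound 3 to compound 1 (1.95 log units; beyond the scatter), so the estimated step is an at least 83-fold lower number from compound 2 to compound 4 (1.92 log units; beyond the scatter). Since compound 1 gives 1100 nM, compound 4 is expected to land near 1200 nM, most likely between 400 nM and 4000 nM.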

Compound 4, half-maximal inhibitory concentration: 1800 nM
For compound 4 the middle estimate is 1.5-fold (0.18 log units) below the measured one; the measured number falls inside the stated range.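

In this assay, chloromethyl in place of 4-nitrophenyl on a carbonyl carbon gave an at least 55-fold lower number from compound 2 to compound 4 (1.74 log units; beyond the scatter), so on the core bearing the chloro group the change runs in the same direction as on the core without it: the same change on two cores in this assay, an at least 90-fold lower number (1.95 log units; beyond the scatter) from compound 3 to compound 1 and an at least 55-fold lower number (1.74 log units; beyond the scatter) from compound 2 to compound 4; the limit leaves it open whether they differ Chloro in place of hydrogen on an aromatic carbon, seen in the chloromethyl pair, gave a 1.6-fold higher number from compound 1 to compound 4 (0.21 log units; within the scatter), so the chloro group makes no readable difference to that pair. Neither step through a 4-nitrophenyl compound gives the true size of the change, and the step between the two 4-nitrophenyl compounds cannot be read at all, for one shared reason: the limit of > 100000 nM in this assay, at which 2 of the 4 values shown sit.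

The compounds shown leave open whether the chloromethyl group itself matters or whether a plain methyl, a longer chain or an unsubstituted phenyl on the same carbonyl carbon would read in the same way. They also leave open how the change would behave on a core with another group on the benzyl ring, such as a methoxy group or an amine, since the change is shown on only two cores.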